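This account rests on a few compounds, and the source may have more. Where it says the series, first, only, none or still open, it means among the compounds named here.

Three measured compounds share a core and carry different groups on it. Compound 1 `COc1ccc(OC)c(-c2nc(C(c3ccccc3)c3ccccc3)sc2CC(=O)O)c1` and compound 2 `NS(=O)(=O)c1ccc(-c2nc(C(c3ccc(F)cc3)c3ccc(F)cc3)sc2CC(=O)O)cc1` sit together at the top: in an in vitro functional assay on HEK285-7 cells for antagonist activity at prostaglandin D2 receptor 2 (Homo sapiens), read by BRET and beta-arrestin recruitment (on this read-out lower numbers stand for smaller maximal responses and higher numbers for larger maximal responses), compound 1 gives 80% and compound 2 gives 80%, a pair within the usual scatter. Compound 3 `O=C(O)Cc1sc(CSc2ccccc2)nc1-c1ccc(Cl)cc1` gives 50% in this assay, beyond the scatter below both. Compound 4 `O=C(O)Cc1sc(C(c2ccc(F)cc2)c2ccc(F)cc2)nc1-c1cn[nH]c1` changes compound 2 in one place: 1H-pyrazol-4-yl in place of 4-sulfamoylphenyl on an aromatic carbon. Among the compounds with values here, no measured pair differs by this change alone. Because compound 1 gives 80% and compound 2 gives 80% with quite different groups at this place, a step no larger than the scatter is expected, leaning slightly downward. Compound 4 is expected to give 72% in this assay, between 45% and 95%, an estimated step of a number 8 percentage points lower from compound 2 to compound 4 (within the scatter).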

Compound 4, largest response reached (reported as efficacy), in percent of the reference or control that the assay uses: 80%
Estimate against measurement, compound 4: 8 percentage points below, within the range that was stated.
By their numbers in this assay, from the lowest: compound 3; then compounds 1, 2 and 4 (each within the scatter of the next).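

In this assay, the direct comparison at this aromatic carbon gives no change at the digits printed from compound 2 to compound 4 (within the scatter), when 1H-pyrazol-4-yl takes the place of 4-sulfamoylphenyl. This single-place pair shows that a five-membered aromatic ring with 2 hetero atoms and 5 heavy atoms can stand where a six-membered carbon ring group with 10 heavy atoms stood, with no step beyond the scatter. Nothing available explains this result. Going by these compounds, whether an amine or a carboxylic acid on this carbon would give a similar number remains open. So does whether this exchange would give the same outcome alongside other groups on the shared core.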